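This account rests on a few compounds, and the source may have more. Where it says the series, first, only, none or still open, it means among the compounds named here.

Measured compounds:
Compound 1 `CC(=O)N1c2ccccc2CCC1C(=O)Nc1ccccc1O` gives 50700 nM in a functional assay on ACHN cells (Homo sapiens) for cytotoxicity, read by sulforhodamine B assay, with a stated time of 72 h; on this read-out higher numbers stand for weaker inhibition of growth and lower numbers for stronger inhibition of growth.
Compound 2 `O=C(Nc1cc(C(F)(F)F)cc(C(F)(F)F)c1)C1CCc2ccccc2N1C(=O)c1ccc(Cl)cc1` gives 2570 nM in this assay.

Within the data shown here, only two compounds have been measured, and compound 1 stands at the highest of the two numbers. Its nearest neighbour is compound 2, whose value is lower by an amount that lies beyond the usual scatter of this assay, so compound 1 is the weaker of the two at inhibiting growth of these cells. Compound 2 differs from compound 1 in more than one place, so the two values alone cannot be read as the effect of a single change.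

The next step keeps the shared core of compound 1 and the hydroxyphenyl anilide and alters only the group on the ring nitrogen: compound 3 `O=C(Nc1ccccc1O)C1CCc2ccccc2N1C(=O)c1ccccc1` carries phenyl in place of methyl on a carbonyl carbon. Among the measured compounds shown here, no step between measured compounds isolates this change. Compound 2, which carries a benzoyl-type group on the same nitrogen, gives 2570 nM, and that lower number leaves room for the expectation that the step from compound 1 to compound 3 lowers the number by a 3.4-fold lower number from compound 1 to compound 3 (0.53 log units; beyond the scatter). Compound 3 is therefore expected to give about 15000 nM, within a range from 4000 nM to 50000 nM.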

Compound 3, concentration for 50% growth inhibition: 4260 nM
Compound 3: the middle estimate sits 3.5-fold (0.55 log units) above what was measured; low and high end bracket the measured number.
By their numbers in this assay, from the lowest: compounds 2 and 3 (each within the scatter of the next); then compound 1.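

Among these compounds, with the hydroxyphenyl anilide and the shared core held fixed, the change from acetyl to benzoyl on the ring nitrogen gives a 12-fold lower number from compound 1 to compound 3 (1.08 log units; beyond the scatter) in this assay, the first step that isolates this position. The group on this carbonyl carbon therefore matters on its own: phenyl in place of methyl, which adds one six-membered aromatic ring of carbon only and no hydrogen-bond donors or acceptors, is enough to produce a large change in growth inhibition without any change elsewhere in the molecule. Nothing available explains why the step is this large.

The compounds shown leave open whether the gain requires an aromatic ring at this place, or whether a saturated cyclohexyl ring, a longer chain such as butanoyl, or an acyl group bearing an amine would give a similar number. From the compounds shown here alone, they also leave the chlorine on the benzoyl group of compound 2 and the trifluoromethyl groups on its anilide unseparated, so the contribution of each to its value remains unknown.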